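The compounds below may be only part of what the source reports. "The series", "measured", "known", "first", "only" and "open" are said of these compounds alone.

The set holds three measured compounds and one that awaits measurement. Compound 3 `CSc1nc(NCc2ccccc2)c2cccnc2n1` carries a phenyl on a saturated chain carbon bound to a nitrogen on an aromatic ring; in a functional assay on HT-29 cells (Homo sapiens) for cytotoxicity, read by MTT assay, with a stated time of 72 h (on this read-out higher numbers stand for weaker inhibition of growth and lower numbers for stronger inhibition of growth), compound 3 gives 87100 nM. Compound 1 `CSc1nc(NCCCCCO)c2cccnc2n1` shares its core and differs from it in one place: 4-hydroxybutyl in place of phenyl on a saturated chain carbon bound to a nitrogen on an aromatic ring. In this assay compound 1 gives 63900 nM, and the step of a 1.4-fold lower number from compound 3 to compound 1 (0.13 log units; within the scatter).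

Compound 2 `CSc1nc(NCc2ccccc2)c2ccccc2n1` has a different core; the difference between the two cores is not broken down here. In this assay compound 2 gives 36500 nM. Its value and that of compound 1 lie within the scatter of one another, while the value of compound 3 stands beyond the scatter from that of compound 2.

Compound 4 `CSc1nc(NCCCCCO)c2ccccc2n1` is not yet measured. It differs from compound 2 in the same way that compound 1 differs from compound 3: 4-hydroxybutyl in place of phenyl on a saturated chain carbon bound to a nitrogen on an aromatic ring. The place reads the same in both cases, so this is the same change made on the other core. The step expected in this assay is a 1.3-fold lower number from compound 2 to compound 4 (0.12 log units; within the scatter), an expectation that rests on the step of a 1.4-fold lower number from compound 3 to compound 1 (0.13 log units; within the scatter), which lies within the scatter. The estimate for compound 4 in this assay is 28000 nM, with a range from 11000 nM to 75000 nM.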

Compound 4, concentration for 50% growth inhibition: > 100000 nM
Compound 4: a limit, no number; the forecaster's own chance of this, stated with the estimate: 15%; middle value at least 3.5-fold (0.55 log units) away from the limit.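

In this assay compound 4 gives > 100000 nM, which is a limit of the assay and not a number: the limit of > 100000 nM in this assay, at which 1 of the 4 values shown sits. Even so, 4-hydroxybutyl in place of phenyl gives an at least 2.7-fold higher number from compound 2 to compound 4 (0.43 log units; beyond the scatter), so in these two pairs the change does not carry over from one core to the other: the same change on two cores in this assay, a 1.4-fold lower number (0.13 log units; within the scatter) from compound 3 to compound 1 and an at least 2.7-fold higher number (0.43 log units; beyond the scatter) from compound 2 to compound 4, at least 3.7-fold (0.57 log units) apart, beyond the scatter of two such steps. This does not show why the two cores part ways, it does not give the true size of the step on the core of compound 2, since only a limit is available there, and with just two cores it says nothing about how the change would behave on any other core.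

The compounds shown leave open whether the split between the cores belongs to the hydroxy group of 4-hydroxybutyl or to its carbon chain, a question that a plain butyl group on both cores could help to settle. They also leave open how an amine or a carboxylic acid in place of that hydroxy group, or a longer chain, would read in this assay on either core.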